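Working notes: aryl thioether change on compound 1

The source may hold more compounds than are shown below. What is called first, only, known or untested is meant among the compounds shown, and "the series" means these compounds.

Measured in a functional assay on HCT-116 cells (Homo sapiens) for inhibition, read by CCK-8 assay, with a stated time of 72 h, tested at 8 uM; a higher number here means more inhibition of growth at the concentration tested, a lower number less inhibition of growth:
compound 1 `Nc1ccccc1NC(=O)c1ccc(CSc2cccc(F)c2)cc1` gives 81.4%
compound 2 `Cc1ccc(SCc2ccc(/C=C/C(=O)Nc3ccccc3N)cc2)cc1` gives 4.93%

Compound 1 stands highest of the two values, and compound 2 lies lower by a margin beyond the usual scatter. For the measured compounds named here, no pair of measured compounds isolates a single structural change, so the size of the next step has no direct measured support.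

Compound 3 `Cc1cc(C)cc(SCc2ccc(C(=O)Nc3ccccc3N)cc2)c1` keeps the core of compound 1 but carries 3,5-dimethylphenyl in place of 3-fluorophenyl on a sulfur and has not yet been measured in this assay.

A moderate loss of growth inhibition is expected, possibly not beyond the scatter. With compound 1 at 81.4% near the top of the read-out, there is more room for a fall than for a rise. The estimated change is a number 13.4 percentage points lower from compound 1 to compound 3 (beyond the scatter) in the direction of less inhibition. For compound 3 the expected value is 68% (estimated range 38% to 88%).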

Compound 3, percent growth inhibition at one concentration: 72.9%
The estimate for compound 3 lay 4.9 percentage points below the measured number, within the range that was stated.
By their numbers in this assay, from the lowest: compound 2; then compounds 3 and 1 (each within the scatter of the next).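

Working notes, result for compound 3: In this assay, 3,5-dimethylphenyl in place of 3-fluorophenyl on a sulfur gives a number 8.5 percentage points lower from compound 1 to compound 3 (within the scatter) and is the first step in the series that isolates a single change. This position therefore accepts a phenyl ring with two methyl groups and no fluorine without a difference that can be separated from the scatter, so the 3-fluorophenyl group is not shown to be required for growth inhibition at the concentration tested. No measurement on hand explains this outcome or assigns it to any property of either group.

From the compounds shown here alone, whether this acceptance extends beyond the two lipid-free aryl groups seen here stays open: a carboxylic acid or an amine on that ring, or a saturated cyclohexyl ring in its place, would test the position far more sharply than another alkyl or halogen variation. The sulfur is also common to compound 1 and compound 3, so the effect of an ether oxygen in its place remains an open question for the series.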